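The source may report more compounds than this note shows. Statements on the series, on what has been measured and on what is new or still open speak of the compounds shown alone.

Compound 1 `O=S(=O)(CCC(F)=C(F)F)c1nc2ccc(OC(F)F)cc2[nH]1` in a functional assay on HepG2 cells (Homo sapiens) for cytotoxicity, read by MTT assay, with a stated time of 48 h (on this read-out lower numbers stand for stronger inhibition and higher numbers for weaker inhibition), gives > 120000 nM, which is a limit of the assay rather than a number.
Compound 2 `O=S(=O)(CCC(F)=C(F)F)c1nc2ccccc2[nH]1` in this assay gives > 120000 nM, again a limit.
Compound 3 `FC(F)=C(F)CCSc1nc2ccccc2[nH]1` in this assay gives > 120000 nM, also a limit.

All three measured compounds therefore sit at the same edge of what the assay can report, a point summed up as the limit of > 120000 nM in this assay, at which 3 of the 3 values shown sit. Compound 1 and compound 2 share a core and differ in one place: difluoromethoxy in place of hydrogen on an aromatic carbon. The step between them in this assay, a step that the two limits leave unreadable from compound 2 to compound 1, cannot be sized because the limit of > 120000 nM in this assay, at which 3 of the 3 values shown sit, holds both of its ends. Compound 3 carries a different core, and how it differs from compound 2 is not broken down here.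

Compound 4 `FC(F)=C(F)CCSc1nc2ccc(OC(F)F)cc2[nH]1` has not yet been measured in this assay. It arises from compound 3 by the same change that turns compound 2 into compound 1: difluoromethoxy in place of hydrogen on an aromatic carbon. The surroundings of the place are described in the same words for both pairs, so the change is the same, not merely the same kind.

For compound 4 the step that the limit leaves unreadable from compound 3 to compound 4 is expected to be small, because the earlier step that the two limits leave unreadable from compound 2 to compound 1 showed no readable movement between its two limits. Since compound 3 itself gives only a limit, the expected outcome for compound 4 in this assay is that it also reaches the limit, and the estimate is 150000 nM, within 60000 nM to 500000 nM.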

Compound 4, half-maximal inhibitory concentration: > 120000 nM
Compound 4 ended at the assay's limit; the forecaster's own chance of this, stated with the estimate: 85%; the middle value does not contradict the limit.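

Compound 3 and compound 4 both end at a limit rather than a number, so the step between them, hydrogen replaced by difluoromethoxy, cannot be read, and the result is simply: the limit of > 120000 nM in this assay, at which 4 of the 4 values shown sit.

The compounds shown leave open what actual number any of the four would give, and whether difluoromethoxy in place of hydrogen alters cytotoxicity in these cells at all.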